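Substituent series on the shared core: tert-butyl to phenyl

A few compounds are considered here, and "the series" means these few. Any claim that something is new, unique, unknown or untested is made for them only; others in the source may bear on it.

Measured compounds:
compound 1 `CC(C)n1nc(-c2cc(C3CCCCC3)on2)c2c(N)ncnc21`: 9500 nM
compound 2 `CC(C)n1nc(-c2cc(C(C)(C)C)on2)c2c(N)ncnc21`: 6120 nM

Both compounds were read in an assay on BaF3 cells for inhibition of proto-oncogene tyrosine-protein kinase receptor Ret (Homo sapiens), read by MTT assay, with a stated time of 48 h; a lower number here means a stronger inhibitor of growth, a higher number a weaker inhibitor of growth. Within the data shown here, compound 2 stands at the low end of the two numbers, but the only step to it, a 1.6-fold lower number from compound 1 to compound 2 (0.19 log units; within the scatter), lies within the scatter, so compounds 1 and 2 are not separated by this assay.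

Compound 3 `CC(C)n1nc(-c2cc(-c3ccccc3)on2)c2c(N)ncnc21` has not been measured. The change from compound 2 is phenyl in place of tert-butyl on an aromatic carbon. Among the measured compounds shown here, the one step that bears on it is the exchange of cyclohexyl for tert-butyl at the same place, a 1.6-fold lower number from compound 1 to compound 2 (0.19 log units; within the scatter), which did not move the number beyond the scatter. For the measured compounds named here, no measured step brings an aromatic group to this place, so there is nothing to set a direction; the data give no basis to expect more than scatter from putting phenyl there. The step from compound 2 to compound 3 is therefore expected to be small, a 1.2-fold lower number from compound 2 to compound 3 (0.09 log units; within the scatter). For compound 3 the expected value in this assay is 5000 nM, with a range of 1500 nM to 20000 nM.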

Compound 3, concentration for 50% growth inhibition: 3460 nM
Beside the measured number, compound 3's estimate is 1.4-fold (0.16 log units) above it, within the range that was stated.
By their numbers in this assay, from the lowest: compounds 3, 2 and 1 (each within the scatter of the next, the first and the last beyond it).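

In this assay, among these compounds, phenyl brings an aromatic ring to this place for the first time, on the aromatic carbon next to the ring oxygen, and its exchange for tert-butyl stays within the scatter, a 1.8-fold lower number from compound 2 to compound 3 (0.25 log units; within the scatter), so these two groups are not separated. Against cyclohexyl, the same group gives the first step at this place that passes the scatter, a 2.7-fold lower number from compound 1 to compound 3 (0.44 log units; beyond the scatter), though only modestly, and with tert-butyl within the scatter of both, only these two ends of the series are told apart. Nothing measured on these compounds speaks to why phenyl and cyclohexyl part in this way.

The three groups shown at this place contain carbon only, so it remains open whether a ring or chain carrying a heteroatom, such as a pyridine ring, an amine or a carboxylic acid, or a phenyl bearing a fluorine or a methoxy group, would move the number further than phenyl does. Also open, on these data alone, is whether the modest step from cyclohexyl to phenyl would hold with a change elsewhere on the shared core.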